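Acylation of the ring amine on the shared core

This account rests on a few compounds, and the source may have more. Where it says the series, first, only, none or still open, it means among the compounds named here.

Measured in a functional assay on Ehrlich cells (Mus musculus) for cytotoxicity, read by trypan blue exclusion; a higher number here means a weaker inhibitor, a lower number a stronger inhibitor:
compound 1 `N#Cc1c(N)[n+]([O-])c2ccc(Cl)cc2[n+]1[O-]` gives 13.5 ug/mL
compound 2 `CNc1c(C#N)[n+]([O-])c2cc(Cl)ccc2[n+]1[O-]` gives only a limit, > 100 ug/mL

Compound 2 sits at the top of what this assay reports: its reading is a limit and not a number, the assay ceiling noted as the limit of > 100 ug/mL in this assay, at which 1 of the 2 values shown sits. For the measured compounds named here, the single measured step, an at least 7.4-fold higher number from compound 1 to compound 2 (0.86 log units; beyond the scatter), is what carries the series from a number to that limit; the change is only a methyl on the amine nitrogen.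

Compound 3 `CC(=O)N(C(C)=O)c1c(C#N)[n+]([O-])c2cc(Cl)ccc2[n+]1[O-]` differs from compound 2 by diacetylamino in place of methylamino on an aromatic carbon. Going by the values given here, no measured step covers a diacetylamino group. Among the compounds with values here, the only step available, an at least 7.4-fold higher number from compound 1 to compound 2 (0.86 log units; beyond the scatter), shows that taking one hydrogen off that nitrogen already pushes the reading to the limit, and compound 3 takes off the other hydrogen too while adding two carbonyls. On that basis compound 3 is expected to stay at or near the limit, with a step of an at least 1.2-fold lower number from compound 2 to compound 3 (0.09 log units; that floor lies within the scatter), none beyond the scatter. The estimate for compound 3 is 80 ug/mL, within 15 ug/mL to 300 ug/mL, with a fair chance that this assay again returns only a limit.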

Compound 3, half-maximal inhibitory concentration: 2.5 ug/mL
Compound 3: middle estimate off by 32-fold (1.51 log units), on the high side; measured number below the stated range.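

In this assay, the amine nitrogen at this position proves open to change in both directions: diacetylamino in place of methylamino gives an at least 40-fold lower number from compound 2 to compound 3 (1.60 log units; beyond the scatter), so removing the last hydrogen from that nitrogen does not keep the reading at the limit. Diacetylamino also moves past the free amine, with a 5.4-fold lower number from compound 1 to compound 3 (0.73 log units; beyond the scatter), so that methylamino and diacetylamino shift the number in opposite directions from amino, and a single trend with substitution on this nitrogen does not fit compounds 1, 2 and 3. The step from compound 2 has a floor and not an exact size, since compound 2 gives only a limit and not a number: the limit of > 100 ug/mL in this assay, at which 1 of the 3 values shown sits.

Still open, going by these compounds, is whether a single acetyl, as in an acetylamino group, is enough for the low reading, or whether a dimethylamino group, which has no amine hydrogen and no carbonyl, would read like compound 2 or like compound 3. Equally open, on these data alone, is whether the reading follows the carbonyls as such, which a longer acyl chain such as propanoyl or a benzoyl group on the same nitrogen would help to test.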